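The source may hold more compounds than are shown below. What is called first, only, known or untested is meant among the compounds shown, and "the series" means these compounds.

Compound 1 `CC(=O)OCCc1c(C)[nH]c(=O)[nH]c1=O`: > 100000 nM
Compound 2 `COc1nc(C)c(CCO)c(OC)n1`: > 100000 nM
Compound 3 `COc1nc(Cl)nc(C)c1CCO`: "not determined" (no result reported)

In a functional assay on MOLT-4 cells (Homo sapiens) for antiproliferative activity, read by MTT assay, with a stated time of 24 h (on this read-out lower numbers stand for stronger inhibition and higher numbers for weaker inhibition), compound 1 reports only a limit, > 100000 nM. Compound 2 likewise gives only a limit in this assay, > 100000 nM. Compound 3 has no result in this assay, "not determined" (no result reported). So compound 2 stands with the limit of > 100000 nM in this assay, at which 2 of the 3 values shown sit, and no measured step in the series places it anywhere beyond that.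

Compound 4 `COc1nc(C)c(CCCl)c(OC)n1` differs from compound 2 by chloro in place of hydroxy on a saturated chain carbon, two bonds along the chain from an aromatic carbon. Nothing measured here supports a step in this assay in either direction, so none beyond the scatter is expected; compound 4 is most likely to return a limit as well.

Compound 4 is accordingly estimated at 100000 nM (range 30000 nM to 300000 nM), the expected step of a number no higher from compound 2 to compound 4 (the limit leaves the size open) being effectively none.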

Compound 4, half-maximal inhibitory concentration: > 100000 nM
Compound 4 gave a limit, no number; the forecaster's own chance of this, stated with the estimate: 80%; the middle value sits exactly at the limit.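

In this assay compound 2 stands at a limit, > 100000 nM. Within the data shown here, compound 4 also stands at a limit, > 100000 nM, so no step between compound 2 and compound 4 can be read. The compounds shown leave open whether chloro and hydroxy on this chain differ at all in this assay.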